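The source may report more compounds than this note shows. Statements on the series, on what has been measured and on what is new or still open speak of the compounds shown alone.

Measured so far in a functional assay on a cell-free system (plasma) for agonist activity at thromboxane A2 receptor (Homo sapiens); a lower number here means a stronger inhibitor, a higher number a weaker inhibitor:
compound 1 `O=C(O)COC/C=C1\C[C@H]2C[C@@H](O)[C@H](/C=N/NC(=O)Nc3ccc(Cl)c(Cl)c3)[C@H]2C1`: 180 nM
compound 2 `O=C(O)COC/C=C1\C[C@H]2C[C@@H](O)[C@H](/C=N/NC(=O)Nc3cccc(Cl)c3)[C@H]2C1`: 1600 nM
compound 3 `O=C(O)CC/C=C1\C[C@H]2C[C@@H](O)[C@H](/C=N/NC(=O)Nc3ccc([N+](=O)[O-])cc3)[C@H]2C1`: 520 nM

Compound 3 stands second highest of the three numbers, between compound 1, whose number is lower, and compound 2, whose number is higher. Among the compounds with values here, the only single-point step among the measured compounds is an 8.9-fold higher number from compound 1 to compound 2 (0.95 log units; beyond the scatter), a change on the aromatic ring. Compound 4 `O=C(O)COC/C=C1\C[C@H]2C[C@@H](O)[C@H](/C=N/NC(=O)Nc3ccc([N+](=O)[O-])cc3)[C@H]2C1` differs from compound 3 in another place: carboxymethoxy in place of carboxymethyl on a saturated chain carbon bound to a double-bonded chain carbon. Within the data shown here, no measured pair isolates this chain change, so the step from compound 1 to compound 2 does not bear on it directly. Compounds 1 and 2 both carry the carboxymethoxy chain and bracket compound 3 on either side, which gives no direction for the chain itself. Compound 4 is therefore expected to stay close to compound 3, with the step of a 1.2-fold lower number from compound 3 to compound 4 (0.06 log units; within the scatter) not expected to exceed the scatter. The estimate for compound 4 in this assay is 450 nM, in a range from 150 nM to 1400 nM.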

Compound 4, half-maximal inhibitory concentration: 190 nM
Compound 4: the middle estimate sits 2.4-fold (0.37 log units) above what was measured; low and high end bracket the measured number.
By their numbers in this assay, from the lowest: compounds 1 and 4 (each within the scatter of the next); then compound 3; then compound 2.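

The chain change now has a reading of its own in this assay: with 4-nitrophenyl held constant, carboxymethoxy in place of carboxymethyl on a saturated chain carbon bound to a double-bonded chain carbon gives a 2.7-fold lower number from compound 3 to compound 4 (0.44 log units; beyond the scatter) and this step lies beyond the scatter. With the carboxymethoxy chain held constant, 4-nitrophenyl in place of 3-chlorophenyl gives an 8.4-fold lower number from compound 2 to compound 4 (0.93 log units; beyond the scatter) and 4-nitrophenyl in place of 3,4-dichlorophenyl gives a 1.1-fold higher number from compound 1 to compound 4 (0.02 log units; within the scatter) so the last two aryl groups are not told apart here. No supporting data are available to explain these steps.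

Going by these compounds, the carboxymethyl chain appears here only with 4-nitrophenyl, so whether the chain step carries over to the chlorinated aryl groups stays open. Also open, on these data alone, is how a longer chain, or a tetrazole in place of the carboxylic acid, would read on this position.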